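The compounds below may be only part of what the source reports. "The series", "measured", "known", "first", "only" and "open" are said of these compounds alone.

Measured so far in an ADME assay on RAW264.7 cells (Mus musculus) for cytotoxicity, read by WST assay; a higher number here means that more compound is tolerated, a lower number that less compound is tolerated:

- compound 1 `O=C(NCc1ccco1)c1ccc(CN2C(=O)c3ccccc3S2(=O)=O)cc1`: compound 1 gives > 100000 nM, a limit of the assay.
- compound 2 `CC(C)(C)OC(=O)N(C(=O)OC(C)(C)C)C(=O)c1ccc(CN2C(=O)c3ccccc3S2(=O)=O)cc1`: compound 2 gives > 100000 nM, a limit of the assay.
- compound 3 `CN(Cc1ccco1)C(=O)c1ccc(CN2C(=O)c3ccccc3S2(=O)=O)cc1`: compound 3 gives > 100000 nM, a limit of the assay.

Compound 3 therefore stands on a limit only, and the two other values shown for the series are limits as well; all three sit at the limit of > 100000 nM in this assay, at which 3 of the 3 values shown sit. Within the data shown here, the one step that connects measured compounds, a step that the two limits leave unreadable from compound 1 to compound 3, methyl in place of hydrogen on an amide-type nitrogen, is unreadable in size because both of its ends are limits.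

The next compound, compound 4 `CC(C)(C)OC(=O)NC(=O)c1ccc(CN2C(=O)c3ccccc3S2(=O)=O)cc1`, differs from compound 3 by (tert-butoxycarbonyl)amino in place of ((furan-2-yl)methyl)(methyl)amino on a carbonyl carbon. Among the measured compounds shown here, no measured step bears on this change. Compound 2 also carries tert-butoxycarbonyl groups on the amide-type nitrogen, and for compound 2 only a limit is known, so it gives no readable size either.

With every value in the series at the same limit, no direction beyond the scatter can be read for this assay, and compound 4 is expected to remain at that limit as well. The estimate for compound 4 in this assay is 150000 nM, with a range from 60000 nM to 400000 nM. The expected step that the limit leaves unreadable from compound 3 to compound 4 is thus essentially flat, and the outcome is most likely to be reported as a limit again.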

Compound 4, concentration lethal to 50% of the cells: > 100000 nM
Compound 4 gave a limit, no number; the forecaster's own chance of this, stated with the estimate: 85%; the middle value does not contradict the limit.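

In this assay compound 4 gives > 100000 nM, a limit of the assay. The steps to compound 4 from compound 1, compound 2 and compound 3 cannot be read in size, because every value rests on the same limit: the limit of > 100000 nM in this assay, at which 4 of the 4 values shown sit.

The compounds shown leave open at what concentration any of them would become lethal to the cells in this assay, and whether any of these changes alters that concentration.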